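The source may report more compounds than this note shows. Statements on the series, on what has been measured and on what is new or still open speak of the compounds shown alone.

In a functional assay on A549 cells (Homo sapiens) for antiproliferative activity, read by MTT assay, with a stated time of 72 h (on this read-out higher numbers stand for weaker inhibition and lower numbers for stronger inhibition), compound 3 `CCCCCCCCNC[C@@H]1OC[C@H](N)[C@H]1O` gives 71800 nM and compound 1 `CCCCCCCCCCCCNC[C@@H]1OC[C@H](N)[C@H]1O` gives 41100 nM, two values within the scatter of each other. Compound 2 `CCCCCCCCCNC[C@@H]1OC[C@H](N)[C@H]1O` reaches only a limit, > 128000 nM. Compound 4 `CCCCCCCCCCNC[C@@H]1OC[C@H](N)[C@H]1O` has ethyl in place of hydrogen on a saturated chain carbon, eight bonds along the chain from an amine nitrogen. Three measured steps also change only the chain length: a 1.7-fold higher number from compound 1 to compound 3 (0.24 log units; within the scatter), an at least 1.7-fold lower number from compound 2 to compound 3 (0.25 log units; that floor lies within the scatter) and an at least 3.1-fold higher number from compound 1 to compound 2 (0.49 log units; beyond the scatter). They follow no single direction, and the closeness of the longer and shorter chains, a 1.7-fold higher number from compound 1 to compound 3 (0.24 log units; within the scatter), suggests no change beyond the scatter in this assay. The expected step is a 1.2-fold lower number from compound 3 to compound 4 (0.06 log units; within the scatter). For compound 4, the estimate is 62000 nM, with an expected range of 30000 nM to 128000 nM.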

Compound 4, half-maximal inhibitory concentration: > 128000 nM
Compound 4: a limit, no number; the forecaster's own chance of this, stated with the estimate: 25%; middle value at least 2.0-fold (0.31 log units) from the limit.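

Compound 4 gives only a limit, not a number. The step from the shorter chain therefore reads only as a floor (an at least 1.7-fold higher number from compound 3 to compound 4 (0.25 log units; that floor lies within the scatter)), while the step from the longer chain of compound 1 passes the scatter (an at least 3.1-fold higher number from compound 1 to compound 4 (0.49 log units; beyond the scatter)). Compound 2 and compound 4 both give limits, and the step between them cannot be read: the limit of > 128000 nM in this assay, at which 2 of the 4 values shown sit.

The compounds shown leave open why compound 3 and compound 1 give numbers while the two chains of intermediate length do not. They also leave open what a chain longer than that of compound 1, or an amine at the chain end, would give.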